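The source may report more compounds than this note shows. Statements on the series, on what has been measured and on what is new or still open speak of the compounds shown alone.

Working notes on the cytotoxicity series. In a functional assay on HeLa cells (Homo sapiens) for cytotoxicity, read by MTT assay (a higher number here means a weaker inhibitor, a lower number a stronger inhibitor), compound 1 `CC(=O)OCCC(=O)O[C@H](CC=C(C)C)C1=CC(=O)c2c(O)ccc(O)c2C1=O` gives 17300 nM, compound 2 `CC(C)=CC[C@@H](OC[C@@H](C)O)C1=CC(=O)c2c(O)ccc(O)c2C1=O` gives 22500 nM and compound 3 `CC[C@@](C)(O)CC(=O)O[C@H](CC=C(C)C)C1=CC(=O)c2c(O)ccc(O)c2C1=O` gives 17900 nM. Compound 3 thus stands second highest of the three numbers, with compound 1 nearest and compound 2 furthest, both within the scatter. Compound 4 `CC(C)=CC[C@@H](OC(=O)C1CCOC1)C1=CC(=O)c2c(O)ccc(O)c2C1=O` carries oxolan-3-yl in place of 2-hydroxy-2-methylbutyl on a carbonyl carbon. For the measured compounds named here, the steps that bear on this are a 1.0-fold higher number from compound 1 to compound 3 (0.01 log units; within the scatter), which also reworked the group carried by the ester carbonyl, and a 1.3-fold lower number from compound 2 to compound 3 (0.10 log units; within the scatter), which swapped the whole oxygen substituent; neither moved the number beyond the scatter. The expectation for compound 4 is therefore no step beyond the scatter, a 1.0-fold higher number from compound 3 to compound 4 (0.00 log units; within the scatter). Compound 4 is estimated at 18000 nM in this assay, expected to lie between 9000 nM and 36000 nM.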

Compound 4, half-maximal inhibitory concentration: 73500 nM
Beside the measured number, compound 4's estimate is 4.1-fold (0.61 log units) below it, outside the stated range (above it).
By their numbers in this assay, from the lowest: compounds 1, 3 and 2 (each within the scatter of the next); then compound 4.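

In this assay the group on this carbonyl carbon proves able to move the number: oxolan-3-yl in place of 2-hydroxy-2-methylbutyl gives a 4.1-fold higher number from compound 3 to compound 4 (0.61 log units; beyond the scatter), whereas the steps among compounds 1, 2 and 3 all stayed within the scatter. The same separation appears in a 4.2-fold higher number from compound 1 to compound 4 (0.63 log units; beyond the scatter) and in a 3.3-fold higher number from compound 2 to compound 4 (0.51 log units; beyond the scatter), so compound 4 stands alone in this set. No measurement available here accounts for this shift.

From the compounds shown here alone, whether the ring itself or the missing hydroxyl sets this step remains open. An open-chain 2-methoxyethyl group or a six-membered oxan-4-yl ring on the same carbonyl carbon would help separate the two.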